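What one methyl may do to compound 1

The source may hold more compounds than are shown below. What is called first, only, known or untested is meant among the compounds shown, and "the series" means these compounds.

Measured so far in a functional assay on OVCAR-3 cells (Homo sapiens) for antiproliferative activity; on this read-out lower numbers stand for stronger inhibition of growth and higher numbers for weaker inhibition of growth
- compound 1 `Oc1cc(-c2ccc3ccccc3c2)nc2ncccc12` gives 8320 nM
- compound 2 `Cc1cnc2[nH]c(-c3cccc(Cl)c3)cc(=O)c2c1` gives 22.4 nM

Compound 1 holds the higher of these two numbers, well beyond the usual scatter, so it inhibits growth more weakly than compound 2. Compound 3 `Cc1ccnc2nc(-c3ccc4ccccc4c3)cc(O)c12` differs from compound 1 by methyl in place of hydrogen on an aromatic carbon, opposite the ring nitrogen (methyl in place of hydrogen on an aromatic carbon). Among the compounds with values here, no measured pair shows what such a change does, so in this assay no step beyond the scatter is expected. The expected change is a 1.4-fold lower number from compound 1 to compound 3 (0.14 log units; within the scatter) (an estimate only). For compound 3 the estimated value is 6000 nM (expected range 1500 nM to 25000 nM).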

Compound 3, concentration for 50% growth inhibition: 1290 nM
Compound 3: middle estimate off by 4.7-fold (0.67 log units), on the high side; measured number below the stated range.
By their numbers in this assay, from the lowest: compound 2; then compound 3; then compound 1.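

In this assay methyl in place of hydrogen on this aromatic carbon, opposite the ring nitrogen, gives a 6.4-fold lower number from compound 1 to compound 3 (0.81 log units; beyond the scatter) and so shows that this position responds to substitution. Even a change of one carbon atom moves the growth-inhibition read-out beyond the usual scatter. No measurement shown here explains why the number falls.

As far as these compounds go, whether the lower number is particular to methyl stays open. An ethyl group, a methoxy group, a chlorine atom or an amine on the same carbon could show how far this trend extends.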